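Methoxy in place of methyl on the aniline ring

The compounds below may be only part of what the source reports. "The series", "measured", "known", "first", "only" and "open" are said of these compounds alone.

Three compounds built on a shared core were measured in a functional assay on A549 cells (Homo sapiens) for cytotoxicity, read by MTT assay, with a stated time of 72 h; on this read-out lower numbers stand for an effect already at smaller amounts and higher numbers for an effect only at larger amounts of compound. Compound 1 `COc1ccc(Nc2cc(C3CCCCC3)oc(=O)c2)cc1` gives 4.62 uM. For the measured compounds named here, compound 2 `COc1ccc(Nc2cc(/C=C/c3ccccc3)oc(=O)c2)cc1` gives 0.11 uM, and the step from the former to the latter, a 42-fold lower number from compound 1 to compound 2 (1.62 log units; beyond the scatter), is the only one-point change among the measured compounds. Compound 3 `Cc1ccc(Nc2cc(-c3ccccc3)oc(=O)c2)cc1` gives 0.067 uM, the lowest of the three numbers; its gap to compound 2 lies within the scatter, while its gap to compound 1 lies beyond it.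

Compound 4 `COc1ccc(Nc2cc(-c3ccccc3)oc(=O)c2)cc1` has not yet been measured in this assay. It differs from compound 3 by methoxy in place of methyl on an aromatic carbon. Going by the values given here, no measured step covers this exchange: the one measured step, a 42-fold lower number from compound 1 to compound 2 (1.62 log units; beyond the scatter), concerns the group on the other end of the core, and compounds 1 and 2 already carry the methoxy that enters here, so they say nothing about methyl against methoxy at this position. The data give no ground for a large move in either direction. The step of a 1.2-fold higher number from compound 3 to compound 4 (0.08 log units; within the scatter) is therefore expected to stay within the scatter. Compound 4 is expected to give about 0.08 uM, with a range from 0.03 uM to 0.25 uM.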

Compound 4, concentration for half-maximal effect: 0.093 uM
For compound 4 the middle estimate is 1.2-fold (0.07 log units) below the measured one, within the range that was stated.
By their numbers in this assay, from the lowest: compounds 3, 4 and 2 (each within the scatter of the next); then compound 1.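

In this assay the exchange of methyl for methoxy, on an aromatic carbon para to a large group, can now be read directly (a 1.4-fold higher number from compound 3 to compound 4 (0.14 log units; within the scatter)): the added oxygen and hydrogen-bond acceptor leave the number within the scatter, so the two groups cannot be told apart here. With methoxy kept in place, phenyl and 2-phenylethenyl also cannot be told apart (a 1.2-fold lower number from compound 2 to compound 4 (0.07 log units; within the scatter)), while phenyl in place of cyclohexyl brings a large step (a 50-fold lower number from compound 1 to compound 4 (1.70 log units; beyond the scatter)), so among these compounds it is the group exchanged for cyclohexyl, and not methyl against methoxy, that goes with a large difference. No evidence is at hand on the cause of any of these steps.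

On these data alone, whether an amine, a carboxylic acid or a longer chain such as butoxy on the same aromatic carbon would also stay within the scatter remains open. Also open, as far as these compounds go, is whether methyl and methoxy would stay this close alongside cyclohexyl or 2-phenylethenyl, since methyl appears here only in a compound carrying phenyl.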